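A few compounds are considered here, and "the series" means these few. Any claim that something is new, unique, unknown or untested is made for them only; others in the source may bear on it.

Series notes. Compound 1 `O=C1CN=C(NC[C@@H]2CCCc3cc(S(=O)(=O)c4cccc(F)c4)ccc32)N1` gives 0.1 nM in an assay on isolated protein for displacement of a labelled ligand from 5-hydroxytryptamine receptor 6 (Homo sapiens); a higher number here means a weaker inhibitor, a lower number a stronger inhibitor. Compound 2 `O=C(NC[C@@H]1CCCc2cc(S(=O)(=O)c3cccc(F)c3)ccc21)c1ncc[nH]1` gives 15.9 nM, and compound 3 `CN(C)C(=O)NC[C@@H]1CCCc2cc(S(=O)(=O)c3cccc(F)c3)ccc21` gives 2.51 nM. Among the three numbers compound 3 holds the second highest: the nearest is compound 2, with a 6.3-fold lower number from compound 2 to compound 3 (0.80 log units; beyond the scatter), and the furthest is compound 1, with a 25-fold higher number from compound 1 to compound 3 (1.40 log units; beyond the scatter). The remaining measured step is a 160-fold higher number from compound 1 to compound 2 (2.20 log units; beyond the scatter).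

Compound 4 `CN(C[C@@H]1CCCc2cc(S(=O)(=O)c3cccc(F)c3)ccc21)C(N)=O` is unmeasured. Relative to compound 3 the change is carbamoyl(methyl)amino in place of (dimethylcarbamoyl)amino on a saturated chain carbon bound to a saturated ring carbon. For the measured compounds named here, none of the measured steps makes a change of this kind: each of them exchanges the whole group on the amine nitrogen, whereas here the hydrogen-bond donor and acceptor counts stay the same and one carbon is lost. The step of a 6.3-fold lower number from compound 2 to compound 3 (0.80 log units; beyond the scatter) is the closest in kind, a swap on a carbonyl carbon, and it was modest; the steps of a 160-fold higher number from compound 1 to compound 2 (2.20 log units; beyond the scatter) and a 25-fold higher number from compound 1 to compound 3 (1.40 log units; beyond the scatter) were large but exchange a ring for a chain or another ring and do not bear directly on this. For compound 4 a step in this assay that stays near the scatter, or at most a modest rise, is expected, a 2.0-fold higher number from compound 3 to compound 4 (0.30 log units; within the scatter). Compound 4 is estimated at 5 nM, between 1.5 nM and 15 nM.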

Compound 4, inhibition constant: 39.8 nM
Compound 4: middle estimate off by 8.0-fold (0.90 log units), on the low side; the whole stated range lies below it.
By their numbers in this assay, from the lowest: compound 1; then compound 3; then compound 2; then compound 4.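

Moving a methyl within the urea, with no change in the donor or acceptor counts, is not a neutral edit at this position in this assay: a 16-fold higher number from compound 3 to compound 4 (1.20 log units; beyond the scatter). Compound 4 is the only one of the four with a methyl on the nitrogen bound to the saturated chain carbon, and it is now the weakest inhibitor shown, with a 2.5-fold higher number from compound 2 to compound 4 (0.40 log units; beyond the scatter) and a 400-fold higher number from compound 1 to compound 4 (2.60 log units; beyond the scatter). The earlier compounds shown here showed the effect of exchanging the whole group, whereas this step shows that the arrangement of methyl groups on a group of nearly the same size can alone produce a large step.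

Compound 4 gains a methyl on the inner nitrogen and loses one from the outer nitrogen in a single step, so carbamoylamino, with no methyl on either nitrogen, and (dimethylcarbamoyl)(methyl)amino, with methyl on both, are the groups that would separate the two contributions. Nothing available here explains the size of this step.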